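Adding a Second Hydroxy Group to the Phenol Ring

A few compounds are considered here, and "the series" means these few. Any claim that something is new, unique, unknown or untested is made for them only; others in the source may bear on it.

Compound 2 `O=C1/C(=C/c2ccccc2)CCC/C1=C\c1cccc(O)c1` gives 28400 nM in an assay on isolated protein for inhibition of Alpha glucosidase (Homo sapiens), with stated times of 5 min and 15 min; on this read-out higher numbers stand for weaker inhibition and lower numbers for stronger inhibition. Within the data shown here, on the two numbers measured so far it holds the lowest; the nearest is compound 1 `O=C1/C(=C/c2ccccc2)CCC/C1=C\c1ccc(O)cc1`, which in this assay gives 42300 nM, and the step of a 1.5-fold lower number from compound 1 to compound 2 (0.17 log units; within the scatter) stays within the scatter. Compound 3 `O=C1/C(=C/c2ccccc2)CCC/C1=C\c1ccc(O)c(O)c1` has not yet been measured. It differs from compound 2 by hydroxy in place of hydrogen on an aromatic carbon. Among the measured compounds shown here, no measured step tests the addition of a hydroxy group; the single step available only moves one hydroxy group to another ring carbon, and it was within the scatter. The account therefore expects for compound 3 a step of about a 1.1-fold lower number from compound 2 to compound 3 (0.06 log units; within the scatter), that is, no change beyond the scatter. Compound 3 is estimated at 25000 nM, with a range from 8000 nM to 70000 nM.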

Compound 3, half-maximal inhibitory concentration: 20300 nM
The estimate for compound 3 lay 1.2-fold (0.09 log units) above the measured number; low and high end bracket the measured number.
By their numbers in this assay, from the lowest: compounds 3, 2 and 1 (each within the scatter of the next, the first and the last beyond it).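

Read against compound 2, hydroxy in place of hydrogen on this aromatic carbon, ortho to a hydroxy group and para to a large group, gives a 1.4-fold lower number from compound 2 to compound 3 (0.15 log units; within the scatter) in this assay, so this addition alone is not separated from the scatter. Read against compound 1, the same kind of change gives a 2.1-fold lower number from compound 1 to compound 3 (0.32 log units; beyond the scatter) and is the first step here to pass beyond the scatter, though it remains modest. Nothing measured alongside these numbers accounts for either step.

The compounds shown leave open whether a methoxy group or an amine at this position would move the number beyond the scatter from compound 2. They also leave open whether a carboxylic acid there would give a larger step than hydroxy does.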